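Replacing ((4-bromophenyl)carbamoyl)amino with 3-hydroxyphenyl

A few compounds are considered here, and "the series" means these few. Any claim that something is new, unique, unknown or untested is made for them only; others in the source may bear on it.

Compound 1 `COc1cc(NC(C)CCCNC(=O)Nc2cccc(F)c2)c2ncccc2c1`: 27000 nM
Compound 2 `COc1cc(NC(C)CCCNC(=O)Nc2ccc(F)cc2)c2ncccc2c1`: 25000 nM
Compound 3 `COc1cc(NC(C)CCCNC(=O)NNC(=O)Nc2ccc(Br)cc2)c2ncccc2c1`: 17000 nM

In a functional assay on SW-620 cells (Homo sapiens) for inhibition, read by MTT assay, with a stated time of 72 h (on this read-out lower numbers stand for stronger inhibition and higher numbers for weaker inhibition), these three compounds sit close together. Compound 3, at 17000 nM, cannot be separated from the other two. The measured steps to it are a 1.6-fold lower number from compound 1 to compound 3 (0.20 log units; within the scatter) and a 1.5-fold lower number from compound 2 to compound 3 (0.17 log units; within the scatter). The fluorine shift gives a 1.1-fold lower number from compound 1 to compound 2 (0.03 log units; within the scatter).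

Compound 4 `COc1cc(NC(C)CCCNC(=O)Nc2cccc(O)c2)c2ncccc2c1` remains unmeasured. It has 3-hydroxyphenyl in place of ((4-bromophenyl)carbamoyl)amino on an amide-type nitrogen. The step from compound 1 to compound 3 exchanges the same leaving group for a different aryl group, so it bears most directly on this change, and it stayed small. The step between compound 1 and compound 2 shows that moving the fluorine made no measurable difference. Among the compounds with values here, no compound with a hydroxyl group has been measured, so the range must stay wide.

On this evidence, no step beyond the scatter is expected, and the estimated change is a 1.3-fold higher number from compound 3 to compound 4 (0.11 log units; within the scatter). For compound 4 the estimated value is 22000 nM, with an expected range from 8000 nM to 50000 nM.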

Compound 4, half-maximal inhibitory concentration: 27000 nM
The estimate for compound 4 lay 1.2-fold (0.09 log units) below the measured number; low and high end bracket the measured number.
By their numbers in this assay, from the lowest: compounds 3, 2, 1 and 4 (each within the scatter of the next).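

In this assay, within the data shown here, hydroxy in place of fluoro on an aromatic carbon gives no change at the digits printed from compound 1 to compound 4 (within the scatter), so the earlier compounds' insensitivity to moving the fluorine now extends to exchanging it for a group with a hydrogen-bond donor. The comparison with the 4-fluorophenyl group gives a 1.1-fold higher number from compound 2 to compound 4 (0.03 log units; within the scatter), and removing the ((4-bromophenyl)carbamoyl)amino group, with its 11 heavy atoms, for 3-hydroxyphenyl, with 7, gives a 1.6-fold higher number from compound 3 to compound 4 (0.20 log units; within the scatter), so neither exchange moves the number beyond the scatter and all four substituents on this amide-type nitrogen remain indistinguishable on this read-out. No measurement is available that could explain why these exchanges leave the number unmoved.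

The compounds shown leave open whether any group on this nitrogen can separate from the others, since every substituent here carries a six-membered aromatic ring of carbon only and a simple alkyl group such as cyclohexyl has no counterpart among them. They also leave open whether an amine or a carboxylic acid on that aromatic ring, in place of hydroxy or fluoro, or a longer chain linking the urea to the shared core, would give a step beyond the scatter.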